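This account rests on a few compounds, and the source may have more. Where it says the series, first, only, none or still open, it means among the compounds named here.

Compound 1 `COc1cc(C(=O)NS(=O)(=O)c2ccccc2C)ccc1Cn1cc(C)c2ccc(NC(=O)CC3CCCC3)cc21` is one of two measured compounds. In a functional assay on trachea for agonist activity at cysteinyl leukotriene receptor (Homo sapiens) (on this read-out lower numbers stand for stronger inhibition and higher numbers for weaker inhibition), compound 1 gives 0.456 nM, the lower of the two numbers. Compound 2 `COc1cc(C(=O)O)ccc1Cn1ccc2ccc(NC(=O)OC3CCCC3)cc21` differs from it in several places, and in this assay compound 2 gives 15.7 nM, a gap beyond the usual scatter. Compound 3 `COc1cc(C(=O)NS(=O)(=O)c2ccccc2C)ccc1Cn1ccc2ccc(NC(=O)CC3CCCC3)cc21` differs from compound 1 in one place: hydrogen in place of methyl on an aromatic carbon. Among the measured compounds shown here, no measured pair shows this change, so the step is expected to be small, toward a slightly higher number and near the edge of the scatter: a 1.6-fold higher number from compound 1 to compound 3 (0.22 log units; within the scatter). Compound 3 is therefore expected to give 0.75 nM in this assay, within 0.3 nM to 2 nM.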

Compound 3, antagonist equilibrium constant: 0.106 nM
Estimate against measurement, compound 3: 7.1-fold (0.85 log units) above; measured number below the stated range.
By their numbers in this assay, from the lowest: compound 3; then compound 1; then compound 2.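

Taking the methyl off this aromatic carbon of the five-membered ring, two ring bonds from the ring nitrogen, gives a 4.3-fold lower number from compound 1 to compound 3 (0.63 log units; beyond the scatter) in this assay and so strengthens inhibition rather than weakening it. The methyl is therefore not needed for strong inhibition in the core of compound 1, and the plain hydrogen does better. No measurement at hand explains why this small change has this effect.

From the compounds shown here alone, whether an ethyl group or a chlorine atom on this carbon would match hydrogen or fall back toward methyl stays open.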